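From trifluoromethyl to cyano on a shared core

The source may report more compounds than this note shows. Statements on the series, on what has been measured and on what is new or still open speak of the compounds shown alone.

Of the compounds shown here, three have been measured in an ADME assay on HEK293 cells (Homo sapiens) for cytotoxicity, read by CellTiter-Glo, with a stated time of 72 h; on this read-out higher numbers stand for an effect only at larger amounts of compound and lower numbers for an effect already at smaller amounts. Compound 1 `CC1=C2CC(C)(C)/C=C/C/C(C)=C\C3=C[C@H](C)C[C@]3(O2)C1=O` gives 26000 nM, compound 3 `CC1=C2CC(C)(C)[C@@H](C)CC(=O)/C(C)=C\C3=C[C@H](C)C[C@]3(O2)C1=O` gives 26000 nM, and compound 2 `C/C1=C/C2=C[C@H](C)C[C@@]23O[C@]2(CC(C)(C)C[C@@H]2[C@@]1(O)C(F)(F)F)[C@@H](C)C3=O` gives 26000 nM, which places it level with both. Compound 4 `C/C1=C/C2=C[C@H](C)C[C@@]23O[C@]2(CC(C)(C)C[C@@H]2[C@@]1(O)C#N)[C@@H](C)C3=O` carries cyano in place of the trifluoromethyl of compound 2 on a saturated ring carbon: cyano in place of trifluoromethyl on a saturated ring carbon. Going by the values given here, no measured pair differs in one place only, so the data hold no direct guide to this replacement. With compound 2 level with the other two at 26000 nM, no step beyond the scatter is expected in this assay. The estimated result is a 1.0-fold lower number from compound 2 to compound 4 (0.02 log units; within the scatter). Compound 4 is expected at 25000 nM, with an estimated range from 12000 nM to 40000 nM.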

Compound 4, half-maximal effective concentration: 8660 nM
Compound 4: middle estimate off by 2.9-fold (0.46 log units), on the high side; the whole stated range lies above it.
By their numbers in this assay, from the lowest: compound 4; then compounds 1, 2 and 3 (each within the scatter of the next).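

In this assay, going by these compounds alone, swapping trifluoromethyl for cyano on this saturated ring carbon gives a 3.0-fold lower number from compound 2 to compound 4 (0.48 log units; beyond the scatter), so the number does respond to what this position carries, which the level values of the earlier compounds could not show. Nothing measured here accounts for this step.

On these data alone, it remains open whether the lower number is particular to cyano or would also follow from another group at this position, such as an amine, a carboxylic acid or a plain methyl group. A single replacement cannot show how far the trend extends.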